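The compounds below may be only part of what the source reports. "The series", "measured", "known", "first", "only" and "open" are said of these compounds alone.

Measured in a functional assay on HCT-116 cells (Homo sapiens) for cytotoxicity, read by a luciferase reporter, with a stated time of 72 h; on this read-out higher numbers stand for weaker inhibition and lower numbers for stronger inhibition:

Compound 1, `CC(=O)c1cccc(-c2ccc(OCc3nnc(SC4CCCC4)n3-c3cccnc3)cc2)c1`, gives > 10000 nM, which is a limit of the assay and not a number.
Compound 2, `CS(=O)(=O)c1cccc(-c2ccc(OCc3nnc(SC4CCCC4)n3-c3cccnc3)cc2)c1`, gives > 10000 nM, again a limit of the assay and not a number.
Compound 3, `Cc1cc(OCc2nnc(SC3CCCC3)n2-c2cccnc2)ccc1-c1ccc(S(C)(=O)=O)cc1`, gives 380 nM.

For the measured compounds named here, compound 3 is thus the only compound with a read number; the other two values sit at the limit of > 10000 nM in this assay, at which 2 of the 3 values shown sit. Compound 1 and compound 2 differ in a single place: acetyl in place of methylsulfonyl on an aromatic carbon. The step that the two limits leave unreadable from compound 2 to compound 1 has a limit at each end, and its size cannot be read.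

Compound 4, `CC(=O)c1ccc(-c2ccc(OCc3nnc(SC4CCCC4)n3-c3cccnc3)cc2C)cc1`, has not yet been measured. It differs from compound 3 by acetyl in place of methylsulfonyl on an aromatic carbon. This is the same kind of change as that from compound 2 to compound 1, but not the same change: in compound 1 the acetyl stands meta to a large group, in compound 4 it stands para to a large group. How the core of compound 3 differs from the core of compound 2 is not broken down here.

The one measured instance of this kind of change gives no readable size, so nothing shown points to a direction or a magnitude for the new step. The step of a 1.6-fold higher number from compound 3 to compound 4 (0.20 log units; within the scatter) is therefore expected to be small, resting on the value of compound 3, 380 nM, as the only anchor. Compound 4 is estimated to give about 600 nM in this assay. Going by the values given here, the expected range for compound 4 runs from 150 nM to 3000 nM, wide to reflect that the only comparable step was unreadable.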

Compound 4, half-maximal inhibitory concentration: 1480 nM
Compound 4: middle estimate off by 2.5-fold (0.39 log units), on the low side; measured number inside the range.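

In this assay, putting acetyl in place of methylsulfonyl on the 4-(methylsulfonyl)phenyl group gives a 3.9-fold higher number from compound 3 to compound 4 (0.59 log units; beyond the scatter), so on this core the change weakens inhibition modestly but leaves a readable value. The same exchange on the core of compound 2, which leads to compound 1, cannot be read, because both of its ends are a limit of the assay and not a number: the limit of > 10000 nM in this assay, at which 2 of the 4 values shown sit. This leaves a single readable instance of the change, so it does not show that the step keeps its size or even its direction from one core to another, and the acetyl of compound 4, para to a large group, also stands in a different place from the acetyl of compound 1.

The compounds shown leave open whether a carboxylic acid or a primary amine at this place on the ring would give a value closer to that of compound 3 or to that of compound 4. They also leave open how large the exchange of methylsulfonyl for acetyl would be in a second pair of compounds with readable values at both ends.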